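This account rests on a few compounds, and the source may have more. Where it says the series, first, only, none or still open, it means among the compounds named here.

Measured in a functional assay on MCF7 cells (Homo sapiens) for antiproliferative activity, read by MTT assay, with a stated time of 48 h; on this read-out lower numbers stand for stronger inhibition and higher numbers for weaker inhibition:
- compound 1 `COc1cccc(C(=O)Nc2cc3cnc(NCCN(C)C)cc3n(C)c2=O)c1`: 43300 nM
- compound 2 `CN(C)CCNc1cc2c(cn1)cc(NC(=O)c1ccc(Cl)cc1)c(=O)n2C`: 3090 nM

Compound 1 holds the higher of the two numbers, well clear of compound 2. Compound 3 `CN(C)CCNc1cc2c(cn1)cc(NC(=O)c1cccc(-c3ccccc3)c1)c(=O)n2C` is reached from compound 1 by phenyl in place of methoxy on an aromatic carbon, meta to a large group. Going by the values given here, only one measured step bears on this, a 14-fold lower number from compound 1 to compound 2 (1.15 log units; beyond the scatter), which is large and beyond the scatter. That step also removes the methoxy, but it brings in a different group, so it is only a loose guide. A lower number is therefore expected in this assay, with the expected change being a 4.8-fold lower number from compound 1 to compound 3 (0.68 log units; beyond the scatter). For compound 3 the estimate is 9000 nM, within an expected range of 2500 nM to 30000 nM.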

Compound 3, half-maximal inhibitory concentration: 1930 nM
For compound 3 the middle estimate is 4.7-fold (0.67 log units) above the measured one, and the stated range ends above it.
By their numbers in this assay, from the lowest: compounds 3 and 2 (each within the scatter of the next); then compound 1.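

In this assay, going by these compounds alone, the exchange of methoxy for phenyl gives a 22-fold lower number from compound 1 to compound 3 (1.35 log units; beyond the scatter) and, unlike the earlier step, leaves the group at this place on the ring as the only change. It shows that this aromatic carbon, meta to a large group, can carry an aromatic ring rather than methoxy while the number falls. Nothing measured here explains the drop. Going by these compounds, it remains open whether a ring is needed at this place, or whether cyclohexyl, a morpholine or a carboxylic acid would serve as well.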